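Shifting the carboxylate and adding chlorine on the aryl ether

The source may report more compounds than this note shows. Statements on the series, on what has been measured and on what is new or still open speak of the compounds shown alone.

Compound 1 `Cc1c(OCCCCOc2ccccc2C(=O)O)ccc(C(=O)CC(C)C)c1O` has the smallest of the three numbers shown: in an assay on HEK293 cells for positive allosteric modulation of metabotropic glutamate receptor 3 (Rattus norvegicus), read by thallium flux, with a stated time of 2.5 min (on this read-out lower numbers stand for smaller maximal responses and higher numbers for larger maximal responses), compound 1 gives 28.1%. Compound 2 `Cc1c(OCCCCOc2ccccc2C(=O)O)ccc(C(=O)CC2CCCC2)c1O` gives 32.9% and compound 3 `Cc1c(OCCCCOc2ccc(C(=O)O)c(Cl)c2)ccc(C(=O)CC2CCCC2)c1C` gives 35.5%; both gaps to compound 1 lie within the scatter. Going by the values given here, the single measured step, a number 4.8 percentage points higher from compound 1 to compound 2 (within the scatter), concerns the chain on the carbonyl, not the aryl ether. Compound 4 `Cc1c(OCCCCOc2ccc(C(=O)O)cc2Cl)ccc(C(=O)CC(C)C)c1O` differs from compound 1 in that aryl ether: 4-carboxy-2-chlorophenyl in place of 2-carboxyphenyl on an oxygen on a saturated carbon. Among the compounds with values here, no measured pair isolates this change; compound 3 carries a chlorinated carboxyphenyl but also differs from compound 2 elsewhere, and their two values show only a gap within the scatter. Compound 4 is therefore expected to move by a number 3.9 percentage points higher from compound 1 to compound 4 (within the scatter), nothing beyond the scatter. In this assay compound 4 is estimated at 32%, ranging from 20% to 45%.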

Compound 4, largest response reached (reported as percent of maximum), in percent of the reference or control that the assay uses: 62.9%
Beside the measured number, compound 4's estimate is 30.9 percentage points below it, outside the stated range (above it).
By their numbers in this assay, from the lowest: compounds 1, 2 and 3 (each within the scatter of the next); then compound 4.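

In this assay, the aryl ether proves a far more responsive place than the chain on the carbonyl: 4-carboxy-2-chlorophenyl in place of 2-carboxyphenyl gives a number 34.8 percentage points higher from compound 1 to compound 4 (beyond the scatter), whereas cyclopentyl in place of isopropyl gave only a number 4.8 percentage points higher from compound 1 to compound 2 (within the scatter). The compounds shown offer no evidence on why this change raises the maximal response. Going by these compounds alone, the single step joins the shifted carboxylic acid and the added chlorine, so their shares remain unresolved. Going by these compounds, whether 4-carboxyphenyl alone, or a fluorine or methyl group in place of the chlorine, would keep the gain stays open.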